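The source may report more compounds than this note shows. Statements on the series, on what has been measured and on what is new or still open speak of the compounds shown alone.

Working notes on the series in an ADME assay on Vero cells (Chlorocebus sabaeus) for inhibition; on this read-out lower numbers stand for higher toxicity in this test and higher numbers for lower toxicity in this test: compound 1 (`COc1ccc(/C=C2\CCC/C(=C\c3ccc(N(C)C)cc3)C2=O)cc1`) gives 392000 nM, and compound 2 (`COc1ccc(/C=C2\CCC/C(=C\c3cccc(OC)c3OC)C2=O)cc1`) gives 401000 nM, level with compound 1 within the scatter. Compound 3 (`COc1ccc(/C=C2\CCC/C(=C\c3cccc(Br)c3)C2=O)cc1`) gives 30000 nM, beyond the scatter under compound 2. Next is compound 4 (`COc1cccc(/C=C2\CCC/C(=C\c3ccccc3)C2=O)c1OC`), which departs from compound 2 by hydrogen in place of methoxy on an aromatic carbon, para to a large group, so 4-methoxyphenyl becomes phenyl. Among the compounds with values here, no measured pair isolates this change, so the expectation is loose. The estimated step of a 2.7-fold lower number from compound 2 to compound 4 (0.43 log units; beyond the scatter) is a move to a lower number, modestly beyond the scatter. The expected value for compound 4 is 150000 nM, within an estimated range of 40000 nM to 450000 nM.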

Compound 4, half-maximal cytotoxic concentration: 33500 nM
Estimate against measurement, compound 4: 4.5-fold (0.65 log units) above, and the stated range ends above it.
By their numbers in this assay, from the lowest: compounds 3 and 4 (each within the scatter of the next); then compounds 1 and 2 (each within the scatter of the next).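

In this assay, within the data shown here, the change from 4-methoxyphenyl to phenyl gives the first step that isolates a single place (a 12-fold lower number from compound 2 to compound 4 (1.08 log units; beyond the scatter)), a large move towards higher toxicity in this test. This position is therefore not indifferent to substitution, and the methoxy group on the aromatic carbon, para to a large group, goes with the higher number in this matched pair. No available measurement bears on the reason for this step.

Open, as far as these compounds go, is whether a hydroxyl group, an amine or a longer alkoxy chain at this place would keep the higher number. Also open, from the compounds shown here alone, is whether the same step recurs with other groups on the far side of the shared core.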